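Bromo at the Phenyl Ring: Expected Shift in Cytotoxicity

The source may report more compounds than this note shows. Statements on the series, on what has been measured and on what is new or still open speak of the compounds shown alone.

Measured compounds:
- compound 1, `COC(=O)c1c(-c2cc3ccccc3oc2=O)nn(-c2ccccc2)c1C(=O)OC`, gives 35000 nM
- compound 2, `CCOC(=O)c1c(-c2cc3ccccc3oc2=O)nn(-c2cccc(Cl)c2)c1C(=O)OCC`, gives 22000 nM
- compound 3, `CCOC(=O)c1c(-c2cc3ccccc3oc2=O)nn(-c2ccc(Br)cc2)c1C(=O)OCC`, gives 250000 nM

In a functional assay on HeLa cells (Homo sapiens) for cytotoxicity, read by MTT assay, with a stated time of 48 h (a lower number here means a stronger inhibitor, a higher number a weaker inhibitor), compound 1 stands second highest of the three numbers. Its nearest neighbour is compound 2, whose value lies within the scatter of that of compound 1, so no order between these two can be read. Compound 3 sits furthest away, and that gap lies beyond the scatter.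

Compound 4, `COC(=O)c1c(-c2cc3ccccc3oc2=O)nn(-c2ccc(Br)cc2)c1C(=O)OC`, is not yet measured. It differs from compound 1 in one place: bromo in place of hydrogen on an aromatic carbon. The group on the aromatic nitrogen thus changes from phenyl to 4-bromophenyl, with the bromine entering para to a large group.

Among the measured compounds shown here, one measured step bears on this change. It is an 11-fold higher number from compound 2 to compound 3 (1.06 log units; beyond the scatter), where 4-bromophenyl likewise arrives, though starting from 3-chlorophenyl and on the ethyl-ester form of the shared core. For the measured compounds named here, no step from phenyl itself to 4-bromophenyl is available, and the ester difference between the two series is untested. Because of an 11-fold higher number from compound 2 to compound 3 (1.06 log units; beyond the scatter), a step of comparable size towards a higher number is expected for compound 4, though with wide uncertainty given the different starting group. The expected step is a 5.7-fold higher number from compound 1 to compound 4 (0.76 log units; beyond the scatter). Compound 4 is therefore estimated at 200000 nM, with a range from 60000 nM to 600000 nM.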

Compound 4, half-maximal inhibitory concentration: 120000 nM
Compound 4: middle estimate off by 1.7-fold (0.22 log units), on the high side; measured number inside the range.
By their numbers in this assay, from the lowest: compounds 2 and 1 (each within the scatter of the next); then compound 4; then compound 3.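

In this assay, among the compounds shown here, the finding of a 3.4-fold higher number from compound 1 to compound 4 (0.54 log units; beyond the scatter) gives the first direct reading of this change from phenyl itself: bromo in place of hydrogen on an aromatic carbon, para to a large group, raises the number on the methyl-ester form of the shared core. Set beside an 11-fold higher number from compound 2 to compound 3 (1.06 log units; beyond the scatter) on the ethyl-ester form, it shows that arrival at 4-bromophenyl goes with a higher number in both series, although that second step starts from 3-chlorophenyl and so is not the same change. Nothing available accounts for this shift.

The compounds shown leave open whether an amine or a carboxylic acid in place of the bromine would move the number in the same direction. They also leave open whether a longer chain on the esters would alter the size of this step.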